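Adding a Methyl to a Cytotoxic Amide Side Chain

This account rests on a few compounds, and the source may have more. Where it says the series, first, only, none or still open, it means among the compounds named here.

Four compounds share a core that carries an amide side chain and an aryl ring. Compound 1 has the structure `C=CC1=C(C(=O)NCCC)C(c2ccc(Cl)c(Cl)c2)OC1` and compound 2 the structure `C=CC1=C(C(=O)NCC(C)C)C(c2ccc(Cl)c(Cl)c2)OC1`. Compound 3 has the structure `C=CC1=C(C(=O)NCCC)C(c2ccc(OC)cc2)OC1` and compound 4, not yet measured, the structure `C=CC1=C(C(=O)NCC(C)C)C(c2ccc(OC)cc2)OC1`. The difference between the core of compound 1 and the core of compound 3 is not broken down here.

In a functional assay on QGY7701 cells (Homo sapiens) for cytotoxicity, read by MTT assay, with a stated time of 24 h (on this read-out higher numbers stand for weaker inhibition and lower numbers for stronger inhibition), compound 1 gives 31300 nM. For compound 2 this assay reports only a limit, > 100000 nM. The change from compound 1 to compound 2 is methyl in place of hydrogen on a saturated chain carbon bound to two saturated chain carbons, and it produced an at least 3.1-fold higher number from compound 1 to compound 2 (0.50 log units; beyond the scatter). For compound 3 this assay again reports only a limit, > 100000 nM. Two of the three values thus sit at the limit of > 100000 nM in this assay, at which 2 of the 3 values shown sit.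

The change from compound 3 to compound 4 is the same kind of change, (methyl in place of hydrogen on a saturated chain carbon bound to two saturated chain carbons). Since compound 3 already sits at a limit, and since the same change weakened inhibition by an at least 3.1-fold higher number from compound 1 to compound 2 (0.50 log units; beyond the scatter), compound 4 is expected to remain at or beyond that limit, and the step that the limit leaves unreadable from compound 3 to compound 4 is an expectation only. The value of compound 4 in this assay is estimated at 200000 nM, with an expected range from 80000 nM to 600000 nM, and most likely the assay will report only a limit.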

Compound 4, half-maximal inhibitory concentration: > 100000 nM
Compound 4: no number, only a limit (the forecaster's own chance of this, stated with the estimate: 85%); the middle value lies beyond the limit too.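

Compound 3 and compound 4 both give only a limit in this assay, so no step can be read between them: the limit of > 100000 nM in this assay, at which 3 of the 4 values shown sit.

The compounds shown leave open how far beyond that limit compound 3 and compound 4 lie, and so whether methyl in place of hydrogen on this chain changes the result with the core of compound 3 as it does with the core of compound 1.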